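The source may report more compounds than this note shows. Statements on the series, on what has been measured and on what is new or still open speak of the compounds shown alone.

Notes on the series. Three compounds on the shared core are measured in an ADME assay on HepG2 cells (Homo sapiens) for cytotoxicity, with a stated time of 72 h; a higher number here means that more compound is needed for the effect, a lower number that less compound is needed. Compound 1 `Cc1cc(NC(=O)Nc2ncccc2C)c2ccccc2n1` gives only the assay limit > 25000 nM. Compound 3 `Cc1cc(NC(=O)Nc2ccc(O)cc2)c2ccccc2n1` likewise gives only the limit > 25000 nM. Compound 2 `Cc1cc(NC(=O)Nc2cccc(Cl)c2)c2ccccc2n1` gives a number, 19000 nM. Compound 3 therefore stands at the limit, where two of the three values sit (the limit of > 25000 nM in this assay, at which 2 of the 3 values shown sit). The step of an at least 1.3-fold higher number from compound 2 to compound 3 (0.11 log units; that floor lies within the scatter) is a floor within the scatter, and the step that the two limits leave unreadable from compound 1 to compound 3 cannot be read. Compound 4 `Cc1cc(NC(=O)Nc2ccc(SC(F)(F)F)cc2)c2ccccc2n1` differs from compound 3 by (trifluoromethyl)sulfanyl in place of hydroxy on an aromatic carbon. Among the measured compounds shown here, no measured step covers this change; the nearest evidence is the floor from compound 2, carrying 3-chlorophenyl, to compound 3. A number somewhat below the limit is expected, so compound 4 is estimated at 15000 nM with range 5000 nM to 25000 nM, an expected step of an at least 1.6-fold lower number from compound 3 to compound 4 (0.22 log units; that floor lies within the scatter).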

Compound 4, half-maximal effective concentration: 20000 nM
The estimate for compound 4 lay 1.3-fold (0.12 log units) below the measured number, within the range that was stated.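

At this position, on an aromatic carbon para to a large group, the exchange of hydroxy for (trifluoromethyl)sulfanyl removes the hydrogen-bond donor and yields a readable number rather than a limit. The exchange gives an at least 1.2-fold lower number from compound 3 to compound 4 (0.09 log units; that floor lies within the scatter), so no change beyond the scatter is established. Only a floor can be read for this step, and compound 3 stays a limit in this series: the limit of > 25000 nM in this assay, at which 2 of the 4 values shown sit.

From the compounds shown here alone, whether an amine or a carboxylic acid at this position would give a step beyond the scatter remains open. Going by these compounds, the full size of this step also remains open.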